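Chloro on the phenyl of compound 3

The source may hold more compounds than are shown below. What is called first, only, known or untested is meant among the compounds shown, and "the series" means these compounds.

In a functional assay on PC-3 cells (Homo sapiens) for inhibition, read by MTT assay, with a stated time of 48 h, tested at 10 uM (a higher number here means more inhibition of growth at the concentration tested, a lower number less inhibition of growth), compound 1 `Cc1cc(=O)c2c(O)cc(OC/C=C/c3ccccc3)c([C@H]3CCN(C)C[C@H]3O)c2o1` gives 18% and compound 2 `Cc1oc2c([C@H]3CCN(C)C[C@H]3O)c(O)cc(O)c2c(=O)c1C(O)c1cccc(Cl)c1` gives 31% at the single concentration tested. Compound 3 `CN1CC[C@H](c2c(O)cc(O)c3c(=O)cc(/C=C/c4ccccc4)oc23)[C@H](O)C1` gives 10% in the same test. That value lies within the scatter of compound 1, while compound 2 stands higher, beyond the scatter.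

Compound 4 `CN1CC[C@H](c2c(O)cc(O)c3c(=O)cc(/C=C/c4ccccc4Cl)oc23)[C@H](O)C1` turns the phenyl of compound 3 into 2-chlorophenyl, with chloro in place of hydrogen on an aromatic carbon and ortho to a large group. For the measured compounds named here, no measured pair isolates this change. Compound 2 at 31% also carries a chlorophenyl but differs from compound 3 elsewhere too, so it offers only weak guidance. A small upward move is expected, and nothing beyond the scatter. The estimated step is a number 4 percentage points higher from compound 3 to compound 4 (within the scatter) and stays within the scatter. In this assay compound 4 is estimated at 14% with 3% to 30% as the expected range.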

Compound 4, percent growth inhibition at one concentration: 22%
For compound 4 the middle estimate is 8 percentage points below the measured one, and the stated range covers the measured number.
By their numbers in this assay, from the lowest: compounds 3, 1, 4 and 2 (each within the scatter of the next, the first and the last beyond it).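

In this assay, the read-out for chloro in place of hydrogen on an aromatic carbon, ortho to a large group, is a number 12 percentage points higher from compound 3 to compound 4 (beyond the scatter). For the compounds shown here, this is the first pair that differs in one place, and it shows that the phenyl of the 2-phenylethenyl group is a position where a single added heavy atom can change growth inhibition at the concentration tested. The data shown offer no measured basis for explaining this step.

The finding rests on one pair, one substituent and one position, so it does not establish a trend. As far as these compounds go, whether fluoro, methoxy or an amine in the same place would give a similar step remains open, as does the effect of chloro on another aromatic carbon of this ring.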